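Aryl swap on the shared core: compound 3 to compound 4

The source may report more compounds than this note shows. Statements on the series, on what has been measured and on what is new or still open speak of the compounds shown alone.

Three analogues share one core and differ only in the phenyl ring attached to it. In a functional assay on SN12C cells (Homo sapiens) for inhibition, read by sulforhodamine B assay, with a stated time of 48 h, tested at 10 uM (a lower number here means less inhibition, a higher number more inhibition at the concentration tested (going by the name of the read-out)), compound 1 `c1ccc(-c2cn3ccnc3c(-c3ccc4ncn(C5CCCCC5)c4c3)n2)cc1` gives 28.8%, compound 2 `O=Cc1ccc(-c2cn3ccnc3c(-c3ccc4ncn(C5CCCCC5)c4c3)n2)cc1` gives 20.7% and compound 3 `Clc1ccc(-c2cn3ccnc3c(-c3ccc4ncn(C5CCCCC5)c4c3)n2)cc1` gives 13.5%. Compound 3 holds the lowest of the three numbers: a number 7.2 percentage points lower from compound 2 to compound 3 (within the scatter) stays within the scatter, whereas a number 15.3 percentage points lower from compound 1 to compound 3 (beyond the scatter) lies beyond it. Compound 4 `COc1ccccc1-c1cn2ccnc2c(-c2ccc3ncn(C4CCCCC4)c3c2)n1` carries 2-methoxyphenyl in place of 4-chlorophenyl on an aromatic carbon. Both measured steps into compound 3 bear on this change, since each installs the chloro that now leaves; they ran downward, by a number 15.3 percentage points lower from compound 1 to compound 3 (beyond the scatter) and a number 7.2 percentage points lower from compound 2 to compound 3 (within the scatter). Among the measured compounds shown here, removing the chloro is therefore expected to lift the read-out modestly, by about a number 8.5 percentage points higher from compound 3 to compound 4 (within the scatter), although no measured step introduces methoxy. In this assay compound 4 is expected at 22%, within 8% to 36%.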

Compound 4, a percentage reported as inhibition, at one concentration (the size of the read-out at that concentration, not a potency): 7.73%
The estimate for compound 4 lay 14.3 percentage points above the measured number, and the stated range ends above it.
By their numbers in this assay, from the lowest: compounds 4, 3, 2 and 1 (each within the scatter of the next, the first and the last beyond it).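

In this assay, exchanging 4-chlorophenyl for 2-methoxyphenyl gives a number 5.8 percentage points lower from compound 3 to compound 4 (within the scatter), so these two aryl groups are not separated at this position. The methoxy analogue does separate from the other two, with a number 13 percentage points lower from compound 2 to compound 4 (beyond the scatter) and a number 21.1 percentage points lower from compound 1 to compound 4 (beyond the scatter), the latter being the direct effect of adding methoxy to the phenyl ring. Nothing available explains these steps. Going by these compounds, whether the methoxy group itself or its ring position sets the number for compound 4 remains open, as does the outcome with an amine or a carboxylic acid on this phenyl ring.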